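Replacing an Aromatic Diol Ring with a Non-Aromatic One

The source may hold more compounds than are shown below. What is called first, only, known or untested is meant among the compounds shown, and "the series" means these compounds.

Of the compounds shown here, three have been tested in a functional assay on cells (Melanoma cell, Homo sapiens) for cytotoxicity, read by sulforhodamine B assay, with a stated time of 48 h; a higher number here means a weaker inhibitor of growth, a lower number a stronger inhibitor of growth. Compound 1, `Oc1ccc(O)c(-c2cc(-c3ccc(Cl)cc3)nn2-c2ccccc2)c1`, carries a 2,5-dihydroxyphenyl group on its shared core and gives 8790 nM in this assay. Compound 3, `O=C1C=CC(=O)C(c2cc(-c3ccc(Cl)cc3)nn2-c2ccccc2)=C1`, differs from it in one place: a group of 8 heavy atoms (6 carbon, 2 oxygen; one six-membered non-aromatic ring of carbon only) in place of a group of 8 heavy atoms (6 carbon, 2 oxygen; one six-membered aromatic ring of carbon only), on an aromatic carbon. That change brought a 7.9-fold higher number from compound 1 to compound 3 (0.90 log units; beyond the scatter). Compound 2, `CC(=O)NS(=O)(=O)c1ccc(-n2nc(-c3ccccc3)cc2-c2cc(O)ccc2O)cc1`, keeps the 2,5-dihydroxyphenyl group but sits on a different core; how the two cores differ is not broken down here. In this assay compound 2 gives 84800 nM, the highest number among the three, and the same assay shows compound 3 at 69400 nM, which lies within the scatter of compound 2.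

Compound 4, `CC(=O)NS(=O)(=O)c1ccc(-n2nc(-c3ccccc3)cc2C2=CC(=O)C=CC2=O)cc1`, is the counterpart of compound 2 in which (a group of 8 heavy atoms (6 carbon, 2 oxygen; one six-membered non-aromatic ring of carbon only) in place of a group of 8 heavy atoms (6 carbon, 2 oxygen; one six-membered aromatic ring of carbon only), on an aromatic carbon). Within the data shown here, this is the same kind of change as the one from compound 1 to compound 3, but the surroundings differ: in compound 2 the place lies next to the ring atom that bears a large group and two ring bonds from the ring atom that bears a phenyl group, whereas in compound 1 it lies next to the ring atom that bears a phenyl group and two ring bonds from the ring atom that bears a 4-chlorophenyl group. If the change acts as it did before, compound 4 is expected to show a 4.7-fold higher number from compound 2 to compound 4 (0.67 log units; beyond the scatter), a step resting on the one precedent of compound 1 to compound 3, a 7.9-fold higher number from compound 1 to compound 3 (0.90 log units; beyond the scatter). On that basis compound 4 is estimated at 400000 nM, within a range from 100000 nM to 2000000 nM.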

Compound 4, concentration for 50% growth inhibition: 92000 nM
For compound 4 the middle estimate is 4.3-fold (0.64 log units) above the measured one; the measured number lies below the stated range.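

In this assay, putting the non-aromatic ring in place of the 2,5-dihydroxyphenyl group on the core of compound 2 gave a 1.1-fold higher number from compound 2 to compound 4 (0.04 log units; within the scatter), so on this core the swap shows no readable effect on growth inhibition. The swap therefore did not carry over from one core to the other with the same size: the same change on two cores in this assay, a 7.9-fold higher number (0.90 log units; beyond the scatter) from compound 1 to compound 3 and a 1.1-fold higher number (0.04 log units; within the scatter) from compound 2 to compound 4, 7.3-fold (0.86 log units) apart, beyond the scatter of two such steps. This shows that a step measured on one core in this series cannot simply be added to another, but two pairs of compounds do not show which feature of the cores sets the size of the step, or what size it would have on a third core.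

The compounds shown leave open whether the 4-chlorophenyl group or the large group on the core of compound 2 matters more for the size of the step, and a core carrying both would help to separate the two. Also open, as far as these compounds go, is how the step would look with a carboxylic acid or an amine in place of that large group, and how a 2,5-dimethoxyphenyl group would compare with the two rings exchanged here.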